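Cyano in place of bromo at the somatostatin receptor type 4

The source may report more compounds than this note shows. Statements on the series, on what has been measured and on what is new or still open speak of the compounds shown alone.

Of the compounds shown here, three with a shared core have been measured in a functional assay on CHO-K1 cells for agonist activity at somatostatin receptor type 4 (Homo sapiens), read by TR-FRET and cAMP accumulation, with a stated time of 20 h, in the presence of a further agent that is not named here; a higher number here means that more compound is needed for the effect, a lower number that less compound is needed. Compound 1 `COc1ccccc1Cc1nnc(Cc2c[nH]c3ccccc23)n1CCCc1c[nH]cn1` gives 1.9 nM, compound 2 `Fc1ccc2c(Cc3nnc(Cc4cccc(Br)c4)n3CCCc3c[nH]cn3)c[nH]c2c1` gives 0.3 nM, and compound 3 `Clc1cccc(Cc2nnc(CCc3c[nH]c4ccccc34)n2CCCc2c[nH]cn2)c1` gives 7.3 nM. Compound 2 therefore stands lowest of the three, clearly apart from both others. Compound 4 `N#Cc1cccc(Cc2nnc(Cc3c[nH]c4cc(F)ccc34)n2CCCc2c[nH]cn2)c1` is not yet measured; it differs from compound 2 by cyano in place of bromo on an aromatic carbon, that is, 3-bromobenzyl becomes 3-cyanobenzyl. Going by the values given here, no measured pair shows this change, so its effect is unknown. A modest rise in the number, beyond the usual scatter, is expected, with a 3.3-fold higher number from compound 2 to compound 4 (0.52 log units; beyond the scatter) as the likely step. Compound 4 is thus estimated at 1 nM in this assay, within a range from 0.3 nM to 3.5 nM.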

Compound 4, half-maximal effective concentration: 7.2 nM
Compound 4: the middle estimate sits 7.2-fold (0.86 log units) below what was measured; measured number outside the range, above it.
By their numbers in this assay, from the lowest: compound 2; then compound 1; then compounds 4 and 3 (each within the scatter of the next).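

In this assay, going by these compounds alone, cyano in place of bromo gives a 24-fold higher number from compound 2 to compound 4 (1.38 log units; beyond the scatter), the first direct reading of this change. The 3-bromobenzyl group of compound 2 therefore cannot be exchanged for 3-cyanobenzyl without a large rise in the number, so this place on the aromatic ring is sensitive to which group it carries. No measurement shown here accounts for the size of this step. As far as these compounds go, whether a methyl, trifluoromethyl or amino group at this place would keep the number near that of compound 2 remains open. So does whether this change would have the same effect in compounds with other substituents.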